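A Methyl Ester Tried Where Fluoro Gave No Cytotoxicity

A few compounds are considered here, and "the series" means these few. Any claim that something is new, unique, unknown or untested is made for them only; others in the source may bear on it.

Three ureas built on one shared core have been tested in an ADME assay on Raji cells (Homo sapiens) for cytotoxicity, with a stated time of 72 h; on this read-out lower numbers stand for an effect already at smaller amounts and higher numbers for an effect only at larger amounts of compound. Compound 1 `COc1ccc(NC(=O)Nc2cc(C)nc3ccccc23)cc1` gives a value that is a limit of the assay, > 25000 nM. Compound 2 `Cc1cc(NC(=O)Nc2ccc(C(=O)O)cc2)c2ccccc2n1` likewise gives only a limit, > 25000 nM. Compound 3 `Cc1cc(NC(=O)Nc2ccc(F)cc2)c2ccccc2n1` also gives a limit, > 25000 nM. Because all three values sit at the limit of > 25000 nM in this assay, at which 3 of the 3 values shown sit, the steps between them cannot be read: a step that the two limits leave unreadable from compound 1 to compound 2, a step that the two limits leave unreadable from compound 1 to compound 3, and a step that the two limits leave unreadable from compound 2 to compound 3. Compound 3 thus stands where every measured compound stands, at the limit, with no number of its own. Compound 4 `COC(=O)c1ccc(NC(=O)Nc2cc(C)nc3ccccc23)cc1` differs from compound 3 by methoxycarbonyl in place of fluoro on an aromatic carbon. Going by the values given here, no measured step bears on this change in a readable way; each of the three is hidden by the limits. In this assay no step beyond the scatter can therefore be foreseen in either direction, and the step expected here is a step that the limit leaves unreadable from compound 3 to compound 4. Compound 4 is therefore expected to give 40000 nM, with a range from 15000 nM to 120000 nM, most likely again reported only as a limit.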

Compound 4, half-maximal effective concentration: 17000 nM
The estimate for compound 4 lay 2.4-fold (0.37 log units) above the measured number; low and high end bracket the measured number.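

In this assay compound 4 is the first compound shown to give a number rather than a limit, so methoxycarbonyl on this aromatic carbon, para to a large group, yields a readable value where fluoro, methoxy and carboxy did not. Methoxycarbonyl in place of fluoro gives an at least 1.4-fold lower number from compound 3 to compound 4 (0.16 log units; that floor lies within the scatter), methyl in place of hydrogen on the oxygen next to the carbonyl group gives an at least 1.4-fold lower number from compound 2 to compound 4 (0.16 log units; that floor lies within the scatter), and methoxycarbonyl in place of methoxy gives an at least 1.4-fold lower number from compound 1 to compound 4 (0.16 log units; that floor lies within the scatter). Each of these is only a floor, and the steps among the three earlier compounds still cannot be read: the limit of > 25000 nM in this assay, at which 3 of the 4 values shown sit.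

The full size of all three steps stays open, as the compounds shown give only their floors. Also open, on these data alone, is whether an ethyl ester, an amide or an amine at this place would give a number in this assay.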